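Moving the fluorine on the benzyl group of compound 2

The compounds below may be only part of what the source reports. "The series", "measured", "known", "first", "only" and "open" are said of these compounds alone.

compound 1 `NC(=O)c1cccc(Cn2cc(-c3ccc4cn[nH]c4c3)ccc2=O)c1` — 106 nM
compound 2 `Nc1n[nH]c2cc(-c3ccc(=O)n(Cc4ccccc4F)c3)ccc12` — 4 nM
compound 3 `Nc1cccc(Cn2cc(-c3ccc4cn[nH]c4c3)ccc2=O)c1` — 84 nM

In an assay for inhibition of MAP kinase-interacting serine/threonine-protein kinase 2 (Homo sapiens), read by luminescence and ADP-Glo, with a stated time of 2 h (on this read-out higher numbers stand for weaker inhibition and lower numbers for stronger inhibition), compound 2 gives 4 nM, the lowest of the three numbers. Compound 3 gives 84 nM and compound 1 gives 106 nM; both gaps to compound 2 lie beyond the scatter, so compound 2 is the most potent of the three. For the measured compounds named here, the only measured step, a 1.3-fold lower number from compound 1 to compound 3 (0.10 log units; within the scatter), concerns the group on the benzyl ring of the shared core and falls within the scatter.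

Compound 4 `Nc1n[nH]c2cc(-c3ccc(=O)n(Cc4cccc(F)c4)c3)ccc12` differs from compound 2 by 3-fluorophenyl in place of 2-fluorophenyl on a saturated chain carbon bound to an aromatic nitrogen. Going by the values given here, no measured step touches the position of the fluorine, so nothing in these data points to a change in either direction. Compound 4 is therefore expected to give a number close to that of compound 2, with a step of a 1.5-fold higher number from compound 2 to compound 4 (0.18 log units; within the scatter) that stays within the scatter. The estimate for compound 4 in this assay is 6 nM, with a range from 2 nM to 20 nM.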

Compound 4, half-maximal inhibitory concentration: 5 nM
Compound 4: the middle estimate sits 1.2-fold (0.08 log units) above what was measured; low and high end bracket the measured number.
By their numbers in this assay, from the lowest: compounds 2 and 4 (each within the scatter of the next); then compounds 3 and 1 (each within the scatter of the next).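

Moving the fluorine gives the first measured step at this place in this assay, a 1.3-fold higher number from compound 2 to compound 4 (0.10 log units; within the scatter), so 3-fluorophenyl and 2-fluorophenyl on a saturated chain carbon bound to an aromatic nitrogen cannot be told apart on this read-out. The earlier compounds shown here offered no step on the fluorine, and this result shows that the low number of compound 2 does not depend on the 2-fluorophenyl arrangement alone, at least against this one alternative. Nothing shown here bears on why the two placings read alike.

As far as these compounds go, it remains open whether the fluorine is needed at all, as a plain phenyl group would show. From the compounds shown here alone, it also remains open how this place responds to larger or different groups on the ring, such as methoxy, an amine or a carboxylic acid.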